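The compounds below may be only part of what the source reports. "The series", "measured", "known", "first", "only" and "open" are said of these compounds alone.

Among the compounds with values here, compound 1, `COc1cc(C)cc(-c2c(-c3ccnc(-c4ccc(N(C)C)cc4)c3)cnn2CC#N)c1`, is one of two compounds measured so far. In a functional assay on UACC-62 cells (Homo sapiens) for cytotoxicity, read by sulforhodamine B assay, with a stated time of 48 h, tested at 0.001 uM (on this read-out lower numbers stand for a stronger effect and higher numbers for a weaker effect at the one concentration tested), compound 1 gives 96%. Compound 2, `COc1cc(C)cc(-c2nn(CC#N)cc2-c2ccnc(-c3ccc(N(C)C)cc3)c2)c1`, gives 91% in this assay, and the two numbers lie within the scatter of each other, so neither compound can be said to act more strongly than the other. Compound 3, `COc1cc(C)cc(-c2c(-c3ccnc(-c4ccc(C(C)=O)cc4)c3)cnn2CC#N)c1`, has not yet been measured. It differs from compound 1 in one place: acetyl in place of dimethylamino on an aromatic carbon. Within the data shown here, no measured step of this kind exists to lean on, so the expected step of a number 2 percentage points lower from compound 1 to compound 3 (within the scatter) is none beyond the scatter. Compound 3 is therefore estimated at 94%, with a range from 82% to 104%.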

Compound 3, a percentage reported as activity, at one concentration (the size of the read-out at that concentration, not a potency): 93%
Compound 3: middle estimate off by 1 percentage points, on the high side; measured number inside the range.
By their numbers in this assay, from the lowest: compounds 2, 3 and 1 (each within the scatter of the next).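

Within the data shown here, the exchange of dimethylamino for acetyl, on an aromatic carbon para to a large group, is the first measured step at this place. In this assay it is a number 3 percentage points lower from compound 1 to compound 3 (within the scatter), so the two groups cannot be told apart at this one concentration. Nothing measured here bears on why the two groups read alike. From the compounds shown here alone, whether a carboxylic acid or a longer chain at this place would give a number beyond the scatter stays open. So does how compound 1 and compound 3 would compare at other concentrations.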